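Nitro in Place of Chloro: the Step from Compound 2 to Compound 3

The source may hold more compounds than are shown below. What is called first, only, known or untested is meant among the compounds shown, and "the series" means these compounds.

Compound 2 `O=C(Nc1ccccc1Cl)c1ccc2cccc(O)c2n1` is one of two measured compounds in an ADME assay on THP-1 cells (Homo sapiens) for cytotoxicity, read by WST assay, with a stated time of 24 h; a higher number here means a weaker inhibitor, a lower number a stronger inhibitor. In this assay compound 2 gives only a limit, > 30000 nM. Its companion compound 1 `O=C(Nc1ccccc1F)c1ccc2cccc(O)c2n1` likewise gives only a limit in this assay, > 30000 nM. For the measured compounds named here, the single measured step, a step that the two limits leave unreadable from compound 1 to compound 2, therefore cannot be read in size, and the sole evidence is the limit of > 30000 nM in this assay, at which 2 of the 2 values shown sit. The unmeasured compound 3 `O=C(Nc1ccccc1[N+](=O)[O-])c1ccc2cccc(O)c2n1` differs from compound 2 by nitro in place of chloro on an aromatic carbon, ortho to a large group. Going by the values given here, no measured step bears on this change with a readable size, so no direction can be taken from the data. Compound 3 is therefore expected to remain at the limit, with the estimated step of a number no higher from compound 2 to compound 3 (the limit leaves the size open) meaning no change beyond the scatter. The estimate for compound 3 in this assay is 30000 nM, with a range from 10000 nM to 100000 nM.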

Compound 3, half-maximal inhibitory concentration: > 30000 nM
Compound 3: no number, only a limit; the forecaster's own chance of this, stated with the estimate: 80%; the middle value sits exactly at the limit.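

No step among compound 1, compound 2 and compound 3 can be read in this assay, since each gives only a limit: the limit of > 30000 nM in this assay, at which 3 of the 3 values shown sit.

The compounds shown leave open whether fluoro, chloro and nitro differ at all in this read-out, and at what concentration any of the three would reach half-maximal inhibition.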